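The compounds below may be only part of what the source reports. "The series", "measured", "known", "first", "only" and "open" are said of these compounds alone.

Compound 3, `CN1CCC(n2cc(S(=O)(=O)c3ccccc3)c3cccnc32)C1`, is measured in an assay on HeLa cells for displacement of a labelled ligand from 5-hydroxytryptamine receptor 6 (Homo sapiens) (a lower number here means a stronger inhibitor, a higher number a weaker inhibitor), where compound 3 gives 2.5 nM. Among the three compounds measured there, compound 3 carries the highest number, yet the gap to compound 1, `O=S(=O)(c1ccccc1F)c1cn(C2CCNC2)c2ncccc12`, which gives 2 nM, and to compound 2, `O=S(=O)(c1cccc(Br)c1)c1cn(C2CCNC2)c2ncccc12`, which gives 1.3 nM, is in both cases within the scatter, so no order among the three can be read from these values.

Compound 4, `CN1CCC(n2cc(S(=O)(=O)c3ccccc3F)c3cccnc32)C1`, differs from compound 3 in one place: fluoro in place of hydrogen on an aromatic carbon, set ortho to a large group. For the measured compounds named here, no measured pair shows this exact change. Going by the values given here, the only single step available, a 1.5-fold lower number from compound 1 to compound 2 (0.19 log units; within the scatter), touches the 2-fluorophenyl ring by exchanging it for a 3-bromophenyl and stays within the scatter; compound 1 and compound 3 differ in two places at once, so their values cannot be split into a contribution of the fluoro alone. Given this, the fluoro is expected to change the number little, and compound 4 is estimated at 2 nM, between 0.8 nM and 5 nM, a step of a 1.3-fold lower number from compound 3 to compound 4 (0.10 log units; within the scatter).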

Compound 4, inhibition constant: 5.6 nM
Compound 4: the middle estimate sits 2.8-fold (0.45 log units) below what was measured; measured number above the stated range.
By their numbers in this assay, from the lowest: compounds 2, 1 and 3 (each within the scatter of the next); then compound 4.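

The fluoro, set ortho to a large group, does move the number at this position: the change from phenyl to 2-fluorophenyl gives a 2.2-fold higher number from compound 3 to compound 4 (0.35 log units; beyond the scatter), a modest step but one beyond the scatter. For the compounds shown here, compound 4 also shows for the first time a single step at the ring amine nitrogen, where methyl in place of hydrogen, with the 2-fluorophenyl kept, gives a 2.8-fold higher number from compound 1 to compound 4 (0.45 log units; beyond the scatter), again modest and beyond the scatter. No measurement at hand explains either step.

Going by these compounds alone, whether the fluoro step depends on the methyl stays open, since no pair shows the same change on a ring with hydrogen on the amine nitrogen. Also open, from the compounds shown here alone, is whether chloro or methoxy in place of the fluoro, or ethyl in place of the methyl, would shift the number in the same way.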